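From 3,4-dichlorobenzyl to benzyl on compound 2

This account rests on a few compounds, and the source may have more. Where it says the series, first, only, none or still open, it means among the compounds named here.

Measured in a functional assay on I10 cells (Mus musculus) for inhibition, read by MTT assay, with a stated time of 72 h; a higher number here means a weaker inhibitor, a lower number a stronger inhibitor:
- Compound 1 `C=CCc1ccc(OCc2ccc(Cl)c(Cl)c2)c(-c2ccc(OCc3ccc(Cl)c(Cl)c3)c(CC=C)c2)c1`: > 50000 nM, a limit and not a number
- Compound 2 `C=CCc1ccc(OCc2ccc(Cl)c(Cl)c2)c(-c2ccc(O)c(CC=C)c2)c1`: 12200 nM

Going by the values given here, compound 2 holds the only true number so far. Compound 3 `C=CCc1ccc(OCc2ccccc2)c(-c2ccc(O)c(CC=C)c2)c1` differs from it by one change phenyl in place of 3,4-dichlorophenyl on a saturated chain carbon bound to an oxygen on an aromatic ring. Among the compounds with values here, the one measured step, an at least 4.0-fold lower number from compound 1 to compound 2 (0.61 log units; beyond the scatter), took away the entire 3,4-dichlorobenzyl group, so it bears only loosely on this different change. With no firm direction from that step, only a small change is expected, a 1.2-fold higher number from compound 2 to compound 3 (0.09 log units; within the scatter). Compound 3 is estimated at 15000 nM, within an expected range of 6000 nM to 40000 nM.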

Compound 3, half-maximal inhibitory concentration: 21800 nM
For compound 3 the middle estimate is 1.5-fold (0.16 log units) below the measured one; the measured number falls inside the stated range.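

In this assay, putting phenyl in place of 3,4-dichlorophenyl gives a 1.8-fold higher number from compound 2 to compound 3 (0.25 log units; within the scatter) and so stays within the usual scatter. The earlier step removed the whole 3,4-dichlorobenzyl group, whereas this one keeps the benzyl frame and shows that, at this position, the two chlorines can go with no clear change in the read-out. Nothing measured here offers a reason for this result.

Still open, going by these compounds, is how this position would respond to a phenyl carrying a single chlorine, or to a different group such as a pyridine, an amine or a carboxylic acid.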